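A few compounds are considered here, and "the series" means these few. Any claim that something is new, unique, unknown or untested is made for them only; others in the source may bear on it.

In an ADME assay on microsomes from liver (Homo sapiens) for metabolic stability (on this read-out higher numbers stand for a longer-lived compound and lower numbers for a shorter-lived compound), compound 1 `C[C@@H]1CCC[C@H](n2cnc(-c3cc(Cl)ccc3-n3cc(Cl)nn3)cc2=O)c2cc(ccn2)-c2c(cnn2C)NC1=O` gives 1.93 h. Compound 2 `C[C@@H]1CCC[C@H](N2CCC(c3cc(Cl)ccc3-n3cc(Cl)nn3)=CC2=O)c2cc(ccn2)-c2c(cnn2C(F)F)NC1=O` gives > 2 h, which is a limit of the assay and not a number. Compound 2 therefore stands at the limit of > 2 h in this assay, at which 1 of the 2 values shown sits. Compound 3 `C[C@@H]1CCC[C@H](N2CCC(c3cc(Cl)ccc3-n3cc(Cl)nn3)=CC2=O)c2cc(ccn2)-c2c(cnn2C)NC1=O` differs from compound 2 by methyl in place of difluoromethyl on an aromatic nitrogen. Within the data shown here, no measured pair isolates this change; compound 1 carries the same methyl group on its own core and gives 1.93 h. The step of a number no higher from compound 2 to compound 3 (the limit leaves the size open) is expected to stay within the usual scatter, with no clear direction. Compound 3 is estimated at 2 h, within 1.2 h to 3.5 h, and may again return only a limit.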

Compound 3, half-life: 1.08 h
Estimate against measurement, compound 3: 1.9-fold (0.27 log units) above; measured number below the stated range.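

This pair gives the first direct read of the change at this position: in this assay, methyl in place of difluoromethyl on an aromatic nitrogen gives an at least 1.8-fold lower number from compound 2 to compound 3 (0.26 log units; that floor lies within the scatter). That floor alone does not separate the two compounds, and the true step may be larger. Compound 2 holds a limit and not a number: the limit of > 2 h in this assay, at which 1 of the 3 values shown sits.

On these data alone, whether the step carries over to the core of compound 1 remains open. So does the read-out with ethyl or trifluoromethyl on that aromatic nitrogen.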